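Hydroxy on the pendant phenyl of compound 3

A few compounds are considered here, and "the series" means these few. Any claim that something is new, unique, unknown or untested is made for them only; others in the source may bear on it.

Compound 3 `CN1CCC[C@H]1COc1cc(-c2ccccc2)cc([N+](=O)[O-])c1` gives 947 nM in an assay on HEK243 cells for displacement of a labelled ligand from Neuronal acetylcholine receptor; alpha3/beta4 (Homo sapiens), read by scintillation counting, with a stated time of 5 min; on this read-out higher numbers stand for weaker inhibition and lower numbers for stronger inhibition. Compound 1 `CN1CCC[C@H]1COc1cccc([N+](=O)[O-])c1` gives 946 nM and compound 2 `CN1CCC[C@H]1COc1cc(C#CCCCCO)cc([N+](=O)[O-])c1` gives 1200 nM; compound 3 sits in the middle of the three numbers, the nearest being compound 1 (a 1.0-fold higher number from compound 1 to compound 3 (0.00 log units; within the scatter)) and the furthest compound 2 (a 1.3-fold lower number from compound 2 to compound 3 (0.10 log units; within the scatter)), both gaps within the scatter. Compound 4 `CN1CCC[C@H]1COc1cc(-c2ccc(O)cc2)cc([N+](=O)[O-])c1` differs from compound 3 by hydroxy in place of hydrogen on an aromatic carbon. Going by the values given here, no measured step alters the phenyl of compound 3 itself; the steps that bear on the change are those at the aromatic carbon of the shared core that carries the pendant group: a 1.3-fold higher number from compound 1 to compound 2 (0.10 log units; within the scatter), a 1.0-fold higher number from compound 1 to compound 3 (0.00 log units; within the scatter) and a 1.3-fold lower number from compound 2 to compound 3 (0.10 log units; within the scatter), every one within the scatter, so neither a 6-hydroxyhex-1-yn-1-yl group carrying a hydroxy nor a plain phenyl moved the number. On that basis the expected step is a 1.0-fold higher number from compound 3 to compound 4 (0.00 log units; within the scatter), none beyond the scatter. Compound 4 is therefore estimated at 950 nM, with a range from 400 nM to 2300 nM.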

Compound 4, inhibition constant: 122 nM
The estimate for compound 4 lay 7.8-fold (0.89 log units) above the measured number; the measured number lies below the stated range.
By their numbers in this assay, from the lowest: compound 4; then compounds 1, 3 and 2 (each within the scatter of the next).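

In this assay, the pendant phenyl responds to a change where the earlier replacements on the shared core did not: hydroxy in place of hydrogen, para to a large group, gives a 7.8-fold lower number from compound 3 to compound 4 (0.89 log units; beyond the scatter) and is beyond the scatter. Phenyl alone gives a 1.0-fold higher number from compound 1 to compound 3 (0.00 log units; within the scatter) within the scatter while 4-hydroxyphenyl in place of the same hydrogen gives a 7.8-fold lower number from compound 1 to compound 4 (0.89 log units; beyond the scatter) so among these compounds the ring alone does not lower the number. A hydroxy alone does not either: compound 2 carries one on its 6-hydroxyhex-1-yn-1-yl chain, yet 4-hydroxyphenyl in place of that chain gives a 9.8-fold lower number from compound 2 to compound 4 (0.99 log units; beyond the scatter) as a step beyond the scatter.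

Nothing available explains why this hydroxy lowers the number. Still open, going by these compounds, is whether the effect is specific to hydroxy, as a methoxy, an amine or a fluorine on the same carbon would show, and whether hydroxy on another carbon of the phenyl gives the same step.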